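A few compounds are considered here, and "the series" means these few. Any claim that something is new, unique, unknown or untested is made for them only; others in the source may bear on it.

Of the compounds shown here, two have so far been measured in an assay on RBL-1 cells with Polyunsaturated fatty acid 5-lipoxygenase (Rattus norvegicus) as the target; on this read-out higher numbers stand for weaker inhibition and lower numbers for stronger inhibition. Compound 1, `COc1ccc(Cc2ccc3ccccc3c2O)cc1`, gives 75 nM in this assay. Compound 2, `COc1ccc2c(O)c(Cc3ccccc3)ccc2c1`, gives 1900 nM in this assay. Of these two numbers, compound 1 has the lower one, and the gap to compound 2 lies beyond the scatter, so compound 1 is the more potent of the pair.

Compound 3, `CN(C)c1ccc(Cc2ccc3ccccc3c2O)cc1`, has not yet been measured. It differs from compound 1 in one place: dimethylamino in place of methoxy on an aromatic carbon. Going by the values given here, no pair of measured compounds shows what this exchange does to the numbers, so its direction cannot be read from the data; a small step is expected, not beyond the scatter in either direction. For compound 3 the estimate in this assay is 100 nM, within a range from 30 nM to 400 nM. That estimate means an expected step of a 1.3-fold higher number from compound 1 to compound 3 (0.12 log units; within the scatter).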

Compound 3, half-maximal inhibitory concentration: 140 nM
Compound 3: middle estimate off by 1.4-fold (0.15 log units), on the low side; the measured number falls inside the stated range.
By their numbers in this assay, from the lowest: compounds 1 and 3 (each within the scatter of the next); then compound 2.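

In this assay, dimethylamino in place of methoxy on this aromatic carbon, para to a large group, gives a 1.9-fold higher number from compound 1 to compound 3 (0.27 log units; within the scatter), so the two compounds cannot be told apart on this read-out. Going by these compounds alone, this is the first measured change at this position, and it shows that the methoxy group can be exchanged for dimethylamino without a step beyond the scatter. Nothing at hand explains why these two groups give such similar numbers.

On these data alone, it remains open what a carboxylic acid, a chlorine atom or a longer chain such as butoxy would do at this place, and whether plain hydrogen would serve as well. Two groups alone cannot show how wide a range of groups this position accepts.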